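Swapping 3-methylphenyl for 4-chlorophenyl in an antiproliferative series

The compounds below may be only part of what the source reports. "The series", "measured", "known", "first", "only" and "open" are said of these compounds alone.

- Compound 1 `CCCN1CCN(c2ccc(S(=O)(=O)Oc3ccccc3C)cc2)C1=O`: > 100000 nM, a limit and not a number
- Compound 2 `CCCN1CCN(c2ccc(S(=O)(=O)Oc3cccc(C)c3)cc2)C1=O`: 28000 nM

Among the measured compounds shown here, in a functional assay on M21 cells (Homo sapiens) for antiproliferative activity, read by sulforhodamine B assay, with a stated time of 48 h (a higher number here means a weaker inhibitor, a lower number a stronger inhibitor), compound 2 gives 28000 nM, the only true number so far. The next structure is compound 3 `CCCN1CCN(c2ccc(S(=O)(=O)Oc3ccc(Cl)cc3)cc2)C1=O`, with 4-chlorophenyl in place of 3-methylphenyl on an oxygen. For the measured compounds named here, only one measured step bears on this, an at least 3.5-fold lower number from compound 1 to compound 2 (0.55 log units; beyond the scatter). That step starts from the limit of > 100000 nM in this assay, at which 1 of the 2 values shown sits, and it exchanges one methylphenyl group for another, so it offers only weak guidance for a chlorine-bearing group. The expected result is no clear shift in either direction, an estimated 1.1-fold higher number from compound 2 to compound 3 (0.03 log units; within the scatter). For compound 3 the estimated value is 30000 nM, with an expected range from 8000 nM to 100000 nM.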

Compound 3, half-maximal inhibitory concentration: 34000 nM
Compound 3: middle estimate off by 1.1-fold (0.05 log units), on the low side; the measured number falls inside the stated range.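

In this assay the exchange gives a 1.2-fold higher number from compound 2 to compound 3 (0.08 log units; within the scatter), so 4-chlorophenyl on this oxygen stands level with 3-methylphenyl. Against 2-methylphenyl, the same group gives an at least 2.9-fold lower number from compound 1 to compound 3 (0.46 log units; beyond the scatter). Compound 1 gives > 100000 nM, a limit and not a number, so that step has no exact size: the limit of > 100000 nM in this assay, at which 1 of the 3 values shown sits.

As far as these compounds go, whether a chlorine and a methyl group match at one and the same ring position stays open, as 3-methylphenyl and 4-chlorophenyl differ in both. Also open, from the compounds shown here alone, is what an unsubstituted phenyl ring, or a ring carrying a methoxy group or an amine, would give on this oxygen.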